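The source may hold more compounds than are shown below. What is called first, only, known or untested is meant among the compounds shown, and "the series" means these compounds.

Measured in an ADME assay on HepG2 2.2.15 cells (Homo sapiens) for cytotoxicity; a higher number here means that more compound is tolerated, a lower number that less compound is tolerated:
- Compound 1 `O=c1[nH]c2ccc(Cl)cc2c(-c2ccccc2Cl)c1CCO`: 380000 nM
- Compound 2 `O=c1c(CCO)c(-c2ccccc2Cl)c2cc(Cl)ccc2n1-c1c(F)cccc1F`: > 2300000 nM, which is a limit of the assay and not a number
- Compound 3 `O=CCc1c(-c2ccccc2Cl)c2cc(Cl)ccc2[nH]c1=O`: 120000 nM

Compound 3 holds the lower of the two actual numbers, 120000 nM, so it is the less well tolerated of the pair it forms with compound 1. The next compound, compound 4 `CC(=O)OCCc1c(-c2ccccc2Cl)c2cc(Cl)ccc2[nH]c1=O`, has acetoxymethyl in place of formyl on a saturated chain carbon bound to an aromatic carbon.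

The measured step that bears most directly on this change is a 3.2-fold lower number from compound 1 to compound 3 (0.50 log units; beyond the scatter), where formyl replaced hydroxymethyl at that same place. Compound 4 also loses the formyl, so a number moving back towards compound 1 at 380000 nM is expected. Acetoxymethyl is not hydroxymethyl, however, and no measured step covers it, so this reasoning is only a rough guide. The other step, an at least 6.0-fold higher number from compound 1 to compound 2 (0.78 log units; beyond the scatter), lies on an aromatic nitrogen, a different place, and adds little here.

In this assay, a modest rise is expected, estimated as a 1.9-fold higher number from compound 3 to compound 4 (0.28 log units; within the scatter). The estimate for compound 4 is 230000 nM, with an expected range of 80000 nM to 700000 nM.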

Compound 4, half-maximal cytotoxic concentration: 27000 nM
The estimate for compound 4 lay 8.5-fold (0.93 log units) above the measured number; the whole stated range lies above it.
By their numbers in this assay, from the lowest: compound 4; then compound 3; then compound 1. At a limit, above all of these: compound 2.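

In this assay the acetoxymethyl group falls below the formyl compound, with a 4.4-fold lower number from compound 3 to compound 4 (0.65 log units; beyond the scatter) and, measured against the hydroxymethyl parent, putting acetyl in place of hydrogen on the oxygen gives a 14-fold lower number from compound 1 to compound 4 (1.15 log units; beyond the scatter). Compound 3 alone showed one replacement at this place lowering the number, and compound 4 now shows a second replacement doing the same, so among the compounds with hydrogen on the aromatic nitrogen, the free hydroxymethyl of compound 1 holds the highest number. Nothing measured here gives a reason for the drop on going to the larger acetoxymethyl group.

From the compounds shown here alone, whether hydroxymethyl is unusual at this place, or whether other groups would also keep the number high, stays open, and an amine, a carboxylic acid or a longer chain ending in a hydroxyl group would help to settle it. Going by these compounds, compound 2, with 2,6-difluorophenyl on the aromatic nitrogen, gives > 2300000 nM, which is a limit of the assay and not a number, and whether that group would also raise the number of compound 4 remains unknown.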